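The source may report more compounds than this note shows. Statements on the series, on what has been measured and on what is new or still open speak of the compounds shown alone.

Measured compounds:
Compound 1 `CCCc1nc2c(-c3ccccc3)cc(-c3ccccc3)nc2[nH]1`: 69 nM
Compound 2 `c1ccc(-c2cc(-c3ccccc3)c3nc[nH]c3n2)cc1`: 180 nM

In an assay on CHO cells for displacement of a labelled ligand from adenosine receptor A3 (Homo sapiens) (a higher number here means a weaker inhibitor, a lower number a stronger inhibitor), compound 2 gives 180 nM, the higher of the two numbers shown, while compound 1 gives 69 nM. Compound 3 `CCC(CC)c1nc2c(-c3ccccc3)cc(-c3ccccc3)nc2[nH]1` has not yet been measured; it differs from compound 2 by pentan-3-yl in place of hydrogen on an aromatic carbon. Within the data shown here, only one measured step bears on this change: taking the propyl off the shared core produced a 2.6-fold higher number from compound 1 to compound 2 (0.42 log units; beyond the scatter). Compound 3 restores an alkyl group at that same place, now pentan-3-yl instead of propyl, so the expectation is a step in the opposite direction, toward a lower number, of roughly that size; whether the branched chain behaves exactly like propyl is not known from these two compounds, so the range is kept wide. Compound 3 is therefore expected to give about 65 nM (from 20 nM to 200 nM), which means an expected step of a 2.8-fold lower number from compound 2 to compound 3 (0.44 log units; beyond the scatter).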

Compound 3, inhibition constant: 171 nM
Beside the measured number, compound 3's estimate is 2.6-fold (0.42 log units) below it, and the stated range covers the measured number.
By their numbers in this assay, from the lowest: compound 1; then compounds 3 and 2 (each within the scatter of the next).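

In this assay, placing pentan-3-yl on the aromatic carbon between two ring nitrogen atoms gives a 1.1-fold lower number from compound 2 to compound 3 (0.02 log units; within the scatter) and so brings no measurable change from having hydrogen there. The comparison of the two alkyl groups gives a 2.5-fold higher number from compound 1 to compound 3 (0.39 log units; beyond the scatter) for ethyl in place of hydrogen on the saturated chain carbon bound to the aromatic carbon, so the benefit of propyl at this place does not carry over to every alkyl group. Nothing available explains why these two chains differ.

Two alkyl groups are too few to show what separates a group that lowers the number from one that does not. A straight butyl chain, a cyclopentyl ring or an amine at this place could help to settle that.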